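Cyclopropyl for methyl on the core: expectation for compound 3

A few compounds are considered here, and "the series" means these few. Any claim that something is new, unique, unknown or untested is made for them only; others in the source may bear on it.

Measured so far:
compound 1 `CCCCc1nc(C)c(CC(=O)OC(C)C)c(=O)n1Cc1ccc(-c2ccccc2-c2noc(=O)[nH]2)cc1` — in an ADME assay on microsomes from liver (Mus musculus) for metabolic stability, with a stated time of 30 min (a higher number here means that more of the compound is left, a lower number that less of the compound is left), compound 1 gives 4%
compound 2 `CC#CCOC(=O)Cc1c(C)nc(CCCC)n(Cc2ccc(-c3ccccc3-c3noc(=O)[nH]3)cc2)c1=O` — in this assay compound 2 gives 18.3%

Compound 1 stands lowest of the two numbers; its nearest neighbour is compound 2, with a number 14.3 percentage points higher from compound 1 to compound 2 (beyond the scatter). Among the measured compounds shown here, that step exchanges but-2-yn-1-yl for isopropyl on an oxygen next to a carbonyl group and is the only step measured.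

Compound 3 `CCCCc1nc(C2CC2)c(CC(=O)OC(C)C)c(=O)n1Cc1ccc(-c2ccccc2-c2noc(=O)[nH]2)cc1` differs from compound 1 by cyclopropyl in place of methyl on an aromatic carbon. For the measured compounds named here, no measured step touches this aromatic carbon, so the step from compound 1 to compound 2 does not bear on the change; the series gives no measured precedent for it. The expectation therefore rests on compound 1 alone, with 4% as anchor, and a step of a number 4 percentage points higher from compound 1 to compound 3 (within the scatter) is expected, within the scatter. For compound 3 the estimate in this assay is 8%, range 1% to 25%.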

Compound 3, percent of the compound remaining: 14%
Beside the measured number, compound 3's estimate is 6 percentage points below it; the measured number falls inside the stated range.
By their numbers in this assay, from the lowest: compounds 1, 3 and 2 (each within the scatter of the next, the first and the last beyond it).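

In this assay, cyclopropyl in place of methyl on the aromatic carbon next to the ring nitrogen gives a number 10 percentage points higher from compound 1 to compound 3 (within the scatter). Among the compounds shown here, this is the first reading at this position: the change from methyl to cyclopropyl, which brings in a three-membered ring, stays within the scatter, while the only earlier step, a number 14.3 percentage points higher from compound 1 to compound 2 (beyond the scatter), with but-2-yn-1-yl in place of isopropyl on the oxygen, lies beyond it. Nothing available explains the result at this position.

Still open is how a dimethylamino group, an ethyl group or a longer chain would read at this aromatic carbon in this assay, since methyl and cyclopropyl are the only groups shown there. Also open, going by these compounds, is whether cyclopropyl on the core and but-2-yn-1-yl on the oxygen would read differently together in one compound.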